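A Methyl Added to the Only Measured Compound

A few compounds are considered here, and "the series" means these few. Any claim that something is new, unique, unknown or untested is made for them only; others in the source may bear on it.

In a functional assay on the whole organism (Abdomen) with Mus musculus as the target (a lower number here means that less compound is needed, a higher number that more compound is needed for the effect), compound 1 `Cc1nc(Cc2c[nH]cn2)c(C)o1` gives > 30 mg/kg, which is a limit of the assay and not a number. Among the compounds with values here, compound 2 `Cc1nc(C)c(Cc2c[nH]cn2)s1` gives 1 mg/kg, the only true number so far. Compound 3 `Cc1nc(C)c(C(C)c2c[nH]cn2)s1` differs from compound 2 by a methyl in place of hydrogen on a saturated chain carbon bound to two aromatic carbons. Within the data shown here, no measured pair yet shows what such a change does in this assay, so no shift beyond the usual scatter is expected. The estimated change is a 1.3-fold lower number from compound 2 to compound 3 (0.10 log units; within the scatter). For compound 3 the estimate is 0.8 mg/kg, with an expected range from 0.15 mg/kg to 5 mg/kg.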

Compound 3, dose for half-maximal effect: > 30 mg/kg
Compound 3: only a limit was reported (the forecaster's own chance of this, stated with the estimate: 10%); middle value at least 37-fold (1.57 log units) away from the limit.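

Within the data shown here, this is the first pair in this assay that differs in one place, and it shows that a single methyl on this saturated chain carbon bound to two aromatic carbons can change the result sharply: an at least 30-fold higher number from compound 2 to compound 3 (1.47 log units; beyond the scatter). Compound 3 gives > 30 mg/kg, which is a limit of the assay and not a number. The full size of the step therefore stays unknown, and this limit recurs among the few values: the limit of > 30 mg/kg in this assay, at which 2 of the 3 values shown sit.

Going by these compounds, whether a hydroxyl, an amine or a longer chain at this carbon would also raise the number remains open. So does whether any group here can keep the value of compound 2.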